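Amide nitrogen substituent exchange in the compound 1 series

The compounds below may be only part of what the source reports. "The series", "measured", "known", "first", "only" and "open" are said of these compounds alone.

Measured so far:
compound 1, `CCCNc1nc(NCc2ccc(C(=O)NCc3ccc(F)cc3)cc2)c2cc(C)ccc2n1`: 2200 nM
compound 2, `CN(C)c1nc(NCc2ccc(NC(=O)c3ccncc3)cc2)c2ccccc2n1`: 11000 nM

In a functional assay on SW480 cells (Homo sapiens) for inhibition, read by luminescence and resazurin assay, with a stated time of 3 days (a higher number here means a weaker inhibitor, a lower number a stronger inhibitor), compound 1 gives 2200 nM, the lower of the two numbers. Compound 2 gives 11000 nM, a gap beyond the scatter; the two structures differ in several places, so no single step can be read from them. Compound 3, `CCCNc1nc(NCc2ccc(C(=O)Nc3ccc(Cl)nc3)cc2)c2cc(C)ccc2n1`, differs from compound 1 only by 6-chloropyridin-3-yl in place of 4-fluorobenzyl on an amide-type nitrogen. Among the compounds with values here, no measured pair isolates this change, so the expected step is a 1.1-fold higher number from compound 1 to compound 3 (0.06 log units; within the scatter), within the scatter. Compound 3 is estimated at 2500 nM, with a range from 800 nM to 8000 nM.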

Compound 3, half-maximal inhibitory concentration: 2100 nM
Compound 3: the middle estimate sits 1.2-fold (0.08 log units) above what was measured; low and high end bracket the measured number.
By their numbers in this assay, from the lowest: compounds 3 and 1 (each within the scatter of the next); then compound 2.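

In this assay, within the data shown here, 6-chloropyridin-3-yl in place of 4-fluorobenzyl on the amide-type nitrogen gives a 1.0-fold lower number from compound 1 to compound 3 (0.02 log units; within the scatter) and is the first step that can be read at a single place. This nitrogen therefore accepts a ring with one hetero atom in place of a ring of carbon only, without a change beyond the scatter. No available evidence bears on this result.

Still open, from the compounds shown here alone, is whether the position stays this permissive with a group carrying no ring, such as a plain butyl chain. A benzoic acid or an aminoalkyl group on this nitrogen is equally untested among the compounds shown.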